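This account rests on a few compounds, and the source may have more. Where it says the series, first, only, none or still open, it means among the compounds named here.

Measured so far:
Compound 1, `COC(=O)c1sc2cc(OC)ccc2c1C#Cc1ccc(F)cc1`, gives 10100 nM.
Compound 2, `COC(=O)c1sc2cc(OC)ccc2c1C#Cc1ccccc1F`, gives 10300 nM.
Compound 3, `COC(=O)c1sc2ccccc2c1C#Cc1ccccc1F`, gives 30200 nM.

All three values come from a functional assay on cells (CNS cell, Homo sapiens) for cytotoxicity, read by sulforhodamine B assay, with a stated time of 48 h; a lower number here means a stronger inhibitor of growth, a higher number a weaker inhibitor of growth. Compound 1 and compound 2 share one core and differ only in the fluorophenyl group on the triple bond; the change 4-fluorophenyl in place of 2-fluorophenyl on a triple-bonded carbon gives a 1.0-fold lower number from compound 2 to compound 1 (0.01 log units; within the scatter), so the two values cannot be told apart. Going by the values given here, compound 3 carries the same 2-fluorophenyl group as compound 2 but on a different core; the change hydrogen in place of methoxy on an aromatic carbon gives a 2.9-fold higher number from compound 2 to compound 3 (0.47 log units; beyond the scatter), the only step here that rises above the scatter.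

Compound 4, `COC(=O)c1sc2ccccc2c1C#Cc1ccc(F)cc1`, has not yet been measured in this assay. It is related to compound 3 by 4-fluorophenyl in place of 2-fluorophenyl on a triple-bonded carbon, which is the same change, at the same place, that turns compound 2 into compound 1. Because that earlier change gave a 1.0-fold lower number from compound 2 to compound 1 (0.01 log units; within the scatter), the step from compound 3 to compound 4 is expected to be small, a 1.0-fold lower number from compound 3 to compound 4 (0.00 log units; within the scatter). Compound 4 is therefore estimated to give 30000 nM in this assay, expected to lie between 15000 nM and 60000 nM.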

Compound 4, concentration for 50% growth inhibition: 56200 nM
Compound 4: middle estimate off by 1.9-fold (0.27 log units), on the low side; the measured number falls inside the stated range.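

In this assay, 4-fluorophenyl in place of 2-fluorophenyl gives a 1.9-fold higher number from compound 3 to compound 4 (0.27 log units; within the scatter), while hydrogen in place of methoxy gives a 5.6-fold higher number from compound 1 to compound 4 (0.75 log units; beyond the scatter). The fluorophenyl change carries over from one core to the other as a small step, with no sign that the core alters its size: the same change on two cores in this assay, a 1.0-fold lower number (0.01 log units; within the scatter) from compound 2 to compound 1 and a 1.9-fold higher number (0.27 log units; within the scatter) from compound 3 to compound 4, 1.9-fold (0.28 log units) apart, within the scatter of two such steps. The methoxy change carries over too, with the number rising both times it is lost, although two pairs of compounds cannot show why this happens or whether it would hold on any further core: the same change on two cores in this assay, a 2.9-fold higher number (0.47 log units; beyond the scatter) from compound 2 to compound 3 and a 5.6-fold higher number (0.75 log units; beyond the scatter) from compound 1 to compound 4, 1.9-fold (0.28 log units) apart, within the scatter of two such steps.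

The compounds shown leave open whether an amine or a hydroxyl group in place of the methoxy would keep the number as low as the methoxy does. They also leave open how a plain phenyl or a chlorophenyl group on the triple bond would compare, and what a carboxylic acid or an amide in place of the methyl ester would do.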